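A few compounds are considered here, and "the series" means these few. Any claim that something is new, unique, unknown or untested is made for them only; others in the source may bear on it.

In a functional assay on the whole organism (strain Kunming) for inhibition, with Mus musculus as the target, with a stated time of 1 h, at a dose of 40 mg/kg by the oral route (on this read-out higher numbers stand for more inhibition at the one dose given (going by the name of the read-out) and lower numbers for less inhibition), three compounds sharing one core have been measured. Compound 1, `Cc1ccc(N2CCN(c3ccc(C(=O)/C=C/c4ccc(Cl)cc4)cc3)CC2)c(C)c1`, gives 25.7%. Compound 2, `O=C(/C=C/c1ccc(Cl)cc1)c1ccc(N2CCN(c3cccc(Cl)c3)CC2)cc1`, gives 5.85%. Compound 3, `COc1ccc(N2CCN(c3ccc(C(=O)/C=C/c4ccc(Cl)cc4)cc3)CC2)cc1`, gives 55.1%, the highest of the three numbers; the two steps reaching it are a number 29.4 percentage points higher from compound 1 to compound 3 (beyond the scatter) and a number 49.3 percentage points higher from compound 2 to compound 3 (beyond the scatter), both beyond the scatter. Compound 1 and compound 2 also differ beyond the scatter, by a number 19.9 percentage points lower from compound 1 to compound 2 (beyond the scatter).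

The next compound is compound 4, `COc1ccccc1N1CCN(c2ccc(C(=O)/C=C/c3ccc(Cl)cc3)cc2)CC1`. It differs from compound 3 in one place: 2-methoxyphenyl in place of 4-methoxyphenyl on an amine nitrogen in a ring. The two steps ending at compound 3, a number 29.4 percentage points higher from compound 1 to compound 3 (beyond the scatter) and a number 49.3 percentage points higher from compound 2 to compound 3 (beyond the scatter), show that swapping the group on the ring nitrogen moves this assay by modest to large amounts, so the swap in compound 4 is expected to matter as well. Among the compounds with values here, no measured pair shows the same methoxy group moved from one spot to another, so the direction rests on the general sensitivity of this position rather than on a matching step. The step expected for compound 4 is a downward one of a number 20.1 percentage points lower from compound 3 to compound 4 (beyond the scatter). Compound 4 is therefore estimated at 35% in this assay, with a range from 10% to 60%.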

Compound 4, a percentage reported as inhibition, in the whole organism at one dose (the size of the read-out at that dose, not a potency): 6.13%
The estimate for compound 4 lay 28.9 percentage points above the measured number; measured number outside the range, below it.
By their numbers in this assay, from the lowest: compounds 2 and 4 (each within the scatter of the next); then compound 1; then compound 3.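

In this assay, moving the methoxy group on the phenyl ring while keeping the same atoms gives a number 49 percentage points lower from compound 3 to compound 4 (beyond the scatter), so at this position the place of a group on the phenyl ring can matter as much as which group it is, something the earlier swaps could not show because each of them also changed the atoms. The 2-methoxyphenyl group also gives up the lead that a methoxy group seemed to offer: there is a number 0.3 percentage points higher from compound 2 to compound 4 (within the scatter), so it cannot be told apart from the 3-chlorophenyl group, and there is a number 19.6 percentage points lower from compound 1 to compound 4 (beyond the scatter), which puts it under the 2,4-dimethylphenyl group. Among these four compounds, then, a methoxy group alone does not go with a high number, since only the 4-methoxyphenyl group of compound 3 stands clear of the rest.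

Nothing available here accounts for this difference between the two methoxy placements. From the compounds shown here alone, it remains open where a 3-methoxyphenyl group would fall, and whether a 4-ethoxyphenyl or 4-hydroxyphenyl group would keep the number seen for compound 3 at 55.1%.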